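A few compounds are considered here, and "the series" means these few. Any claim that something is new, unique, unknown or untested is made for them only; others in the source may bear on it.

In a functional assay on thoracic aorta for inhibition of Voltage-gated L-type calcium channel (Rattus norvegicus) (on this read-out lower numbers stand for stronger inhibition and higher numbers for weaker inhibition), compound 1 `CC1=NC(C)=C(C(=O)O)C(c2cccc(Cl)c2)/C1=C(\O)OC/C=C/c1ccc(Cl)cc1` gives 5.8 nM, and compound 2 `CC1=NC(C)=C(C(=O)O)C(c2cccc(Cl)c2)/C1=C(\O)OC/C=C/c1ccc(C)cc1` gives 6.8 nM. These two differ in only one spot, and the step from one to the other is small: a 1.2-fold higher number from compound 1 to compound 2 (0.07 log units; within the scatter). Compound 3 `CC1=NC(C)=C(C(=O)O)C(c2cccc(Cl)c2)/C1=C(\O)OC/C=C/c1ccncc1` gives 320 nM in this assay, the highest and therefore weakest number of the three, set well apart from both neighbours by a 55-fold higher number from compound 1 to compound 3 (1.74 log units; beyond the scatter) and a 47-fold higher number from compound 2 to compound 3 (1.67 log units; beyond the scatter). Compound 4 `CC1=NC(C)=C(C(=O)O)C(c2cccc(Cl)c2)/C1=C(\O)OC/C(C)=C/c1ccccc1` has not yet been measured in this assay. It differs from compound 3 in one place: 1-methyl-2-phenylethenyl in place of 2-(pyridin-4-yl)ethenyl on a saturated chain carbon bound to an oxygen on an unsaturated carbon. Going by the values given here, two measured steps bear on this change. Going from a carbon-only six-membered ring to the ring holding one nitrogen was costly, as seen in a 55-fold higher number from compound 1 to compound 3 (1.74 log units; beyond the scatter) and a 47-fold higher number from compound 2 to compound 3 (1.67 log units; beyond the scatter). Among the compounds with values here, compound 4 removes that nitrogen again and returns to a carbon-only ring, while also adding a methyl on the chain, a change with no measured precedent here. For compound 4 a large step back toward lower numbers is expected, roughly undoing that loss: a 32-fold lower number from compound 3 to compound 4 (1.51 log units; beyond the scatter). Compound 4 is therefore expected to reach about 10 nM, with a range from 3 nM to 40 nM, the untested methyl widening that range.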

Compound 4, half-maximal inhibitory concentration: 2.8 nM
Beside the measured number, compound 4's estimate is 3.6-fold (0.55 log units) above it; measured number outside the range, below it.
By their numbers in this assay, from the lowest: compound 4; then compounds 1 and 2 (each within the scatter of the next); then compound 3.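

In this assay, replacing 2-(pyridin-4-yl)ethenyl with 1-methyl-2-phenylethenyl gives a 110-fold lower number from compound 3 to compound 4 (2.06 log units; beyond the scatter), and the same group also improves on both earlier compounds with a carbon-only ring, through a 2.4-fold lower number from compound 2 to compound 4 (0.39 log units; beyond the scatter) and a 2.1-fold lower number from compound 1 to compound 4 (0.32 log units; beyond the scatter), which makes compound 4 the strongest inhibitor of the four. The earlier compounds shown here showed only that chloro and methyl on the ring gave values within the scatter of each other, whereas this result shows that the ring needs neither group for strong inhibition when a methyl sits on the chain, and that this pair of changes brings a modest gain over either of them. No measurement here accounts for that gain or for the large gap to compound 3.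

Going by these compounds, two things change at once in these steps, so the shares of the chain methyl and of the loss of the ring substituent remain unknown. Also open, on these data alone, is how an ethyl in place of the chain methyl, or an amine on the phenyl ring, would affect the number in this assay.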